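A few compounds are considered here, and "the series" means these few. Any claim that something is new, unique, unknown or untested is made for them only; others in the source may bear on it.

Measured compounds:
compound 1 `COc1cc(NC(C)CCCNC(=O)NNC(=O)N(CCO)CCO)c2ncccc2c1`: > 250000 nM
compound 2 `COc1cc(NC(C)CCCNC(=O)N(C)C(c2ccccc2)c2ccccc2)c2ncccc2c1`: 10000 nM

In a functional assay on MOLT-4 cells (Homo sapiens) for inhibition, read by MTT assay, with a stated time of 4 days (a lower number here means a stronger inhibitor, a higher number a weaker inhibitor), compound 1 gives > 250000 nM, which is a limit of the assay rather than a number. Compound 1 therefore stands at the limit of > 250000 nM in this assay, at which 1 of the 2 values shown sits, and its true potency is not known beyond that limit. In this assay, among the compounds with values here, compound 2 gives 10000 nM, and only this one numeric value exists among the two measured compounds.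

Compound 3 `COc1cc(NC(C)CCCNC(=O)NNC(=O)NCCO)c2ncccc2c1` differs from compound 1 by hydrogen in place of 2-hydroxyethyl on an amide-type nitrogen. Within the data shown here, no step between measured compounds mirrors this change, so no measured guide exists for its size or direction. Compound 3 is expected to remain weak, with a step from compound 1 of an at least 1.2-fold lower number from compound 1 to compound 3 (0.09 log units; that floor lies within the scatter), amounting to no change beyond the scatter, because compound 1 sits at the limit of > 250000 nM in this assay, at which 1 of the 2 values shown sits, and shares the rest of its structure with compound 3. For compound 3 the estimate in this assay is 200000 nM, within a range from 50000 nM to 500000 nM.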

Compound 3, half-maximal inhibitory concentration: > 250000 nM
Compound 3 gave a limit, no number; the forecaster's own chance of this, stated with the estimate: 70%; at least 1.2-fold (0.09 log units) between middle value and limit.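

In this assay compound 3 gives > 250000 nM as a limit and not a number. Within the data shown here, with compound 1 also at a limit, no step from compound 1 to compound 3 can be read: the limit of > 250000 nM in this assay, at which 2 of the 3 values shown sit.

The compounds shown leave open whether hydrogen in place of 2-hydroxyethyl changes potency at all.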